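The source may hold more compounds than are shown below. What is called first, only, known or untested is meant among the compounds shown, and "the series" means these compounds.

Of the compounds shown here, three sharing one core have been measured in a functional assay on HL-60 cells (Homo sapiens) for antiproliferative activity, with a stated time of 24 h; a higher number here means a weaker inhibitor, a lower number a stronger inhibitor. Compound 1 `NC(=O)c1c(NC(=O)c2ccccc2F)sc2c1CCN(Cc1cccc(Cl)c1)C2` gives 19800 nM, compound 2 `NC(=O)c1c(NC(=O)c2ccccc2F)sc2c1CCN(Cc1ccc(Cl)cc1Cl)C2` gives 13100 nM, and compound 3 `NC(=O)c1c(NC(=O)c2ccccc2F)sc2c1CCN(C(=S)Nc1ccccc1Cl)C2` gives 12500 nM. The steps to compound 3 are small: a 1.6-fold lower number from compound 1 to compound 3 (0.20 log units; within the scatter) and a 1.0-fold lower number from compound 2 to compound 3 (0.02 log units; within the scatter), so all three numbers sit together within the scatter, as does a 1.5-fold lower number from compound 1 to compound 2 (0.18 log units; within the scatter).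

Compound 4 `NC(=O)c1c(NC(=O)c2ccccc2F)sc2c1CCN(C(=O)Nc1ccccc1Cl)C2` is the next step: a group of 10 heavy atoms (7 carbon, 1 nitrogen, 1 oxygen, 1 chlorine; one six-membered aromatic ring of carbon only) in place of a group of 10 heavy atoms (7 carbon, 1 nitrogen, 1 sulfur, 1 chlorine; one six-membered aromatic ring of carbon only), on an amine nitrogen in a ring. For the measured compounds named here, none of the measured steps exchanges sulfur for oxygen, so none bears directly on this change; every change tried so far on that ring nitrogen has stayed within the scatter. The expected step is therefore no change at the digits printed from compound 3 to compound 4 (within the scatter), no movement beyond the scatter. Compound 4 is expected to give about 12500 nM, between 5000 nM and 31000 nM.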

Compound 4, half-maximal inhibitory concentration: 32700 nM
For compound 4 the middle estimate is 2.6-fold (0.42 log units) below the measured one, outside the stated range (above it).
By their numbers in this assay, from the lowest: compounds 3, 2, 1 and 4 (each within the scatter of the next, the first and the last beyond it).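

For the compounds shown here, on this amine nitrogen in a ring, exchanging one sulfur for one oxygen gives a step beyond the scatter in this assay (a 2.6-fold higher number from compound 3 to compound 4 (0.42 log units; beyond the scatter)), which no earlier pair showed. (2-Chlorophenyl)carbamoyl also separates from 2,4-dichlorobenzyl (a 2.5-fold higher number from compound 2 to compound 4 (0.40 log units; beyond the scatter)), but not from 3-chlorobenzyl (a 1.7-fold higher number from compound 1 to compound 4 (0.22 log units; within the scatter)), so the position responds only modestly. Nothing measured here accounts for the sulfur-to-oxygen difference.

Still open, from the compounds shown here alone, is whether the same exchange gives a similar step with an unsubstituted phenyl ring in place of the 2-chlorophenyl group. Going by these compounds, how an acetyl or methanesulfonyl group on this nitrogen would compare also remains unknown.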